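Aniline swap on the shared core, nitro to methoxy

The source may hold more compounds than are shown below. What is called first, only, known or untested is meant among the compounds shown, and "the series" means these compounds.

Compound 1 `Cc1cnc(Nc2ccc([N+](=O)[O-])cc2)nc1Nc1nc2ccccc2s1` was run in a functional assay on PC-3 cells (Homo sapiens) for antiproliferative activity, read by MTT assay, with a stated time of 48 h; on this read-out lower numbers stand for stronger inhibition and higher numbers for weaker inhibition. In this assay compound 1 gives only a limit, > 50000 nM. Compound 2 `Cc1cnc(Nc2ccc(S(N)(=O)=O)cc2)nc1Nc1nc2ccccc2s1` likewise gives only a limit in this assay, > 50000 nM. The step that the two limits leave unreadable from compound 1 to compound 2 stays unreadable because both values sit at the limit of > 50000 nM in this assay, at which 2 of the 2 values shown sit. Compound 3 `COc1cccc(Nc2ncc(C)c(Nc3nc4ccccc4s3)n2)c1` differs from compound 1 by 3-methoxyphenyl in place of 4-nitrophenyl on a nitrogen on an aromatic ring. Going by the values given here, no measured step bears on this change, and the one step known is unreadable. In this assay compound 3 is expected to give 60000 nM, within 15000 nM to 200000 nM. The expected step is a step that the limit leaves unreadable from compound 1 to compound 3.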

Compound 3, half-maximal inhibitory concentration: > 50000 nM
Compound 3: only a limit was reported; the forecaster's own chance of this, stated with the estimate: 65%; the middle value does not contradict the limit.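

No step can be read from compound 1 to compound 3, or from compound 1 to compound 2, because each value is a limit and not a number: the limit of > 50000 nM in this assay, at which 3 of the 3 values shown sit.

The compounds shown leave open whether the value in this assay shifts with any change at this nitrogen on the shared core.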